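The source may report more compounds than this note shows. Statements on the series, on what has been measured and on what is new or still open speak of the compounds shown alone.

Of the compounds shown here, two carry numbers so far in a functional assay on BT-474 cells (Homo sapiens) for inhibition, read by MTT assay, with a stated time of 5 days; on this read-out lower numbers stand for stronger inhibition and higher numbers for weaker inhibition. Compound 1 (`Cc1cc(Nc2nc(NCc3ccc(F)cc3F)nc3[nH]ncc23)n[nH]1`) gives 3220 nM, and compound 2 (`Cc1cc(Nc2nc(NCc3ccc(Cl)cc3)nc3c2cnn3C2CCOCC2)n[nH]1`) gives 18300 nM, the higher of the two numbers, with a gap beyond the scatter. Among the measured compounds shown here, these two compounds differ in more than one place, so no single change can be read from that gap, and this assay offers no measured step between compounds that differ in one place.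

Compound 3 (`Cc1cc(Nc2nc(NCc3ccc(F)cc3F)nc3c2cnn3C2CCOCC2)n[nH]1`) departs from compound 2 in one place: 2,4-difluorophenyl in place of 4-chlorophenyl on a saturated chain carbon bound to a nitrogen on an aromatic ring. In words, this puts 2,4-difluorophenyl in place of 4-chlorophenyl on a saturated chain carbon bound to a nitrogen on an aromatic ring.

For the measured compounds named here, the only guide is compound 1, which carries the same 2,4-difluorophenyl group and stands at 3220 nM. It differs elsewhere too, so it supports only a cautious expectation. A modest move toward a lower number is expected, and it may not clear the scatter: the estimated change is a 2.0-fold lower number from compound 2 to compound 3 (0.31 log units; beyond the scatter). The estimated value for compound 3 is 9000 nM, with an expected range of 3000 nM to 25000 nM.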

Compound 3, half-maximal inhibitory concentration: 2350 nM
Estimate against measurement, compound 3: 3.8-fold (0.58 log units) above; the measured number lies below the stated range.
By their numbers in this assay, from the lowest: compounds 3 and 1 (each within the scatter of the next); then compound 2.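

In this assay the position on the saturated chain carbon bound to a nitrogen on an aromatic ring now has its first single-place reading: 2,4-difluorophenyl in place of 4-chlorophenyl gives a 7.8-fold lower number from compound 2 to compound 3 (0.89 log units; beyond the scatter) with the oxan-4-yl group held constant, so this position responds clearly to the aryl group it carries. The second reading concerns the aromatic nitrogen, where oxan-4-yl in place of hydrogen gives a 1.4-fold lower number from compound 1 to compound 3 (0.14 log units; within the scatter) with 2,4-difluorophenyl held constant, so no separate effect of that change can be claimed on this read-out. The two steps rest on one pair each and describe only these three compounds.

As far as these compounds go, it remains open whether the step at the aryl position depends on both fluorines or on one of them, and 4-fluorophenyl at this place would separate the loss of chlorine from the entry of the second fluorine. From the compounds shown here alone, it is also open whether the flat response at the aromatic nitrogen extends to a group such as piperidin-4-yl or a longer chain bearing a carboxylic acid, and no supporting measurement bears on the reason for either step.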